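The source may report more compounds than this note shows. Statements on the series, on what has been measured and on what is new or still open speak of the compounds shown alone.

Compound 2 `N#C/C(=C\C=C(/Cl)c1ccc(Br)cc1)C(=O)c1c[nH]c2ccccc12` serves as the reference point. In a functional assay on MCF7 cells (Homo sapiens) for cytotoxicity, read by sulforhodamine B assay, with a stated time of 48 h (on this read-out lower numbers stand for stronger inhibition of growth and higher numbers for weaker inhibition of growth), compound 2 gives 72500 nM. Compound 1 `COc1ccc2[nH]cc(C(=O)/C(C#N)=C/C=C(\Cl)c3ccc(Br)cc3)c2c1` differs from it by methoxy in place of hydrogen on an aromatic carbon and in this assay compound 1 gives 79900 nM, so that a 1.1-fold higher number from compound 2 to compound 1 (0.04 log units; within the scatter). Compound 3 `COc1ccc(/C(Cl)=C/C=C(\C#N)C(=O)c2c[nH]c3ccccc23)cc1` differs from compound 2 by methoxy in place of bromo on an aromatic carbon, which is how the two cores differ; in this assay compound 3 gives 47300 nM, and a 1.5-fold lower number from compound 2 to compound 3 (0.19 log units; within the scatter). All three values sit within the usual scatter of one another, so none of them can be set apart from the others.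

Compound 4 `COc1ccc(/C(Cl)=C/C=C(\C#N)C(=O)c2c[nH]c3ccccc23)cc1OC` has not yet been measured. It differs from compound 3 by methoxy in place of hydrogen on an aromatic carbon. Going by the values given here, this is the same kind of change as the one from compound 2 to compound 1, but not the same change: there the added group sat on a ring that is part of a fused system, meta and para to a fused ring, whereas here it sits on a six-membered carbon ring, ortho to a methoxy group and meta to a large group. Because the earlier step was a 1.1-fold higher number from compound 2 to compound 1 (0.04 log units; within the scatter), a step of similar size is expected here, namely a 1.1-fold higher number from compound 3 to compound 4 (0.02 log units; within the scatter). Compound 4 is therefore estimated to give 50000 nM in this assay.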

Compound 4, concentration for 50% growth inhibition: 44200 nM
Compound 4: middle estimate off by 1.1-fold (0.05 log units), on the high side; low and high end bracket the measured number.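

In this assay, methoxy in place of hydrogen on the aromatic carbon ortho to a methoxy group gives a 1.1-fold lower number from compound 3 to compound 4 (0.03 log units; within the scatter), so this step cannot be told from no change. Set beside the earlier step, the same change reads alike on the two cores: the same change on two cores in this assay, a 1.1-fold higher number (0.04 log units; within the scatter) from compound 2 to compound 1 and a 1.1-fold lower number (0.03 log units; within the scatter) from compound 3 to compound 4, 1.2-fold (0.07 log units) apart, within the scatter of two such steps This shows only that the change left the number within the scatter on both cores; it does not show that a step of real size would carry from one core to the other, and it rests on just two pairs of compounds, with the methoxy on a different ring in each.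

Going by these compounds, the aromatic groups compared here are only hydrogen, bromo and methoxy, so it stays open whether any group at these places can move the number in this assay beyond the scatter. On these data alone, how an amine, a carboxylic acid or a longer chain in place of the added methoxy would read, and whether such a step would match on both cores, also remains open.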